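A few compounds are considered here, and "the series" means these few. Any claim that something is new, unique, unknown or untested is made for them only; others in the source may bear on it.

Of the compounds shown here, three built on one shared core have been measured in an assay on HEK293 cells for positive allosteric modulation of metabotropic glutamate receptor 5 (Homo sapiens), read by FLIPR; on this read-out higher numbers stand for an effect only at larger amounts of compound and lower numbers for an effect already at smaller amounts. Compound 3 `O=C([C@@H]1CC2CCC1C2)N1CC(c2nc(-c3ccccc3)no2)C1` gives 400 nM, the lowest of the two numbers. Compound 1 `O=C(C1CCC2(CCC2)CC1)N1CC(c2nc(-c3cccc(Cl)c3)no2)C1` gives 1100 nM. Compound 2 `COC1CCN(C(=O)N2CC(c3nc(-c4cccc(Cl)c4)no3)C2)CC1` reaches only > 10000 nM, which is a limit of the assay rather than a number. Going by the values given here, the single measured step, an at least 9.0-fold higher number from compound 1 to compound 2 (0.95 log units; beyond the scatter), concerns the amide side, where one value sits at the limit of > 10000 nM in this assay, at which 1 of the 3 values shown sits. Compound 4 `O=C([C@@H]1CC2CCC1C2)N1CC(c2nc(-c3cccc(Cl)c3)no2)C1` differs from compound 3 by chloro in place of hydrogen on an aromatic carbon. Among the compounds with values here, no measured step touches this aromatic position, so nothing measured here argues for a large shift in either direction. A step of a 1.1-fold lower number from compound 3 to compound 4 (0.06 log units; within the scatter) is therefore expected. Compound 4 is estimated at 350 nM, likely between 100 nM and 1200 nM.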

Compound 4, half-maximal effective concentration: 98 nM
Compound 4: middle estimate off by 3.6-fold (0.55 log units), on the high side; the measured number lies below the stated range.
By their numbers in this assay, from the lowest: compound 4; then compound 3; then compound 1. At a limit, above all of these: compound 2.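

Going by these compounds alone, this is the first measured change on the aromatic ring, and chloro in place of hydrogen there gives a 4.1-fold lower number from compound 3 to compound 4 (0.61 log units; beyond the scatter). With the 3-chlorophenyl kept, changing the group on the carbonyl carbon gives an 11-fold lower number from compound 1 to compound 4 (1.05 log units; beyond the scatter), and also an at least 100-fold lower number from compound 2 to compound 4 (2.00 log units; beyond the scatter). That last step rests on a limit for compound 2, not on a number: the limit of > 10000 nM in this assay, at which 1 of the 4 values shown sits.

From the compounds shown here alone, whether a bromo, methyl or methoxy group on this aromatic carbon would match chloro stays open. So does whether the same exchange would also lower the number with the group of compound 1 on the carbonyl carbon.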